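The compounds below may be only part of what the source reports. "The series", "measured", "known", "first", "only" and "open" are said of these compounds alone.

Of the compounds shown here, three of one series have been measured in an assay on HEK293 cells for inhibition of transient receptor potential cation channel subfamily M member 8 (Homo sapiens), read by FLIPR, with stated times of 5 min and 3 min; on this read-out higher numbers stand for weaker inhibition and lower numbers for stronger inhibition. Compound 1 `CCOC(=O)c1sc(-c2ccc(C)cc2)nc1O` gives 160 nM. Compound 3 `CCn1nnc(-c2sc(-c3cccc(O)c3)nc2O)n1` gives 239 nM. Compound 2 `CCON(C)C(=O)c1sc(-c2cccc(F)c2)nc1O` gives 1680 nM, the highest of the three numbers, which on this read-out means the weakest inhibition among them; its gap to compound 3 and its larger gap to compound 1 both lie beyond the usual scatter of repeated measurements. These three compounds differ from one another in more than one place, so none of these gaps can be tied to a single structural change.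

Compound 4 `O=C(c1sc(-c2cccc(F)c2)nc1O)N1CCCOC1` has not yet been measured in this assay. It differs from compound 2 in one place, on a carbonyl carbon whose other neighbour is an aromatic carbon: a group of 6 heavy atoms (4 carbon, 1 nitrogen, 1 oxygen; one six-membered non-aromatic ring with 2 hetero atoms) in place of a group of 5 heavy atoms (3 carbon, 1 nitrogen, 1 oxygen; no ring), on a carbonyl carbon. The counts of hydrogen-bond donors and acceptors stay the same; an open chain gives way to a ring.

For the measured compounds named here, no measured pair among the three compounds shows a change of this kind, so the expectation rests on little beyond the value of compound 2. The step of a 1.7-fold lower number from compound 2 to compound 4 (0.23 log units; within the scatter) is expected to be a modest one downward, quite possibly within the scatter. Compound 4 is estimated at 1000 nM, with a range from 300 nM to 3500 nM.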

Compound 4, half-maximal inhibitory concentration: > 100000 nM
Compound 4: a limit, no number; the forecaster's own chance of this, stated with the estimate: 5%; at least 100-fold (2.00 log units) between middle value and limit.
By their numbers in this assay, from the lowest: compounds 1 and 3 (each within the scatter of the next); then compound 2. At a limit, above all of these: compound 4.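

On the carbonyl carbon, a group with one six-membered non-aromatic ring with 2 hetero atoms in place of the open-chain ethoxy(methyl)amino group gives an at least 59-fold higher number from compound 2 to compound 4 (1.77 log units; beyond the scatter) in this assay, which means much weaker inhibition. Compound 4 gives > 100000 nM, which is a limit of the assay and not a number, so the true size of this step stays unknown: the limit of > 100000 nM in this assay, at which 1 of the 4 values shown sits.

The earlier compounds shown here differ in more than one place and could tie no gap to a single change, whereas this pair shows that one change on the carbonyl carbon, with the counts of hydrogen-bond donors and acceptors unchanged, can take inhibition out of the measurable range.

On these data alone, whether the loss comes from the ring as such or from its oxygen stays open, as does how a piperidine ring, a morpholine ring or a dimethylamino group would behave on the same carbonyl carbon. Also open, as far as these compounds go, is whether the same change would have a similar effect with the other aromatic groups carried by compound 1 and compound 3.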